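The source may report more compounds than this note shows. Statements on the series, on what has been measured and on what is new or still open speak of the compounds shown alone.

The two compounds already measured and the one still to be measured share a common core and were examined in a functional assay on HEL cells (Homo sapiens) for cytotoxicity, read by microscopy; on this read-out higher numbers stand for lower toxicity in this test and lower numbers for higher toxicity in this test. Compound 1 `Cc1cn([C@@H]2O[C@@H]3COC(=O)[C@]3(OS(C)(=O)=O)[C@H]2O)c(=O)[nH]c1=O` is the simpler of the two measured structures. In this assay compound 1 gives >= 400000 nM, which is a limit of the assay and not a measured number. Compound 2 `COC(=O)NC1=CS(=O)(=O)O[C@@]12[C@@H](CO[Si](C)(C)C(C)(C)C)O[C@@H](n1cc(C)c(=O)n(C)c1=O)[C@@H]2O[Si](C)(C)C(C)(C)C` carries a (methoxycarbonyl)amino group on the core. In this assay compound 2 gives >= 50000 nM, again a limit of the assay rather than a number. Within the data shown here, compound 2 thus stands at the limit of >= 50000 nM in this assay, at which 1 of the 2 values shown sits, and the only other value shown is likewise a limit, (the limit of >= 400000 nM in this assay, at which 1 of the 2 values shown sits); with both readings being limits, no step between measured compounds can be worked out, and no direction of change is known from the data.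

Compound 3 `Cc1cn([C@@H]2O[C@H](CO[Si](C)(C)C(C)(C)C)[C@@]3(OS(=O)(=O)C=C3NCCC(N)=O)[C@H]2O[Si](C)(C)C(C)(C)C)c(=O)n(C)c1=O` differs from compound 2 in one place: 2-carbamoylethyl in place of methoxycarbonyl on an amine nitrogen. Among the measured compounds shown here, with no measured step to lean on, the expected change from this swap is a number no higher from compound 2 to compound 3 (the limit leaves the size open), that is, none beyond the usual scatter. Compound 3 is therefore expected to read about 50000 nM in this assay, with a range from 10000 nM to 400000 nM, and most likely again only as a limit.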

Compound 3, minimum cytotoxic concentration: >= 80000 nM
Compound 3: only a limit was reported; the forecaster's own chance of this, stated with the estimate: 80%; middle value at least 1.6-fold (0.20 log units) from the limit.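

In this assay compound 3 gives >= 80000 nM, which is a limit of the assay and not a number. Compound 2 gives >= 50000 nM, also a limit. Among these compounds, no step from compound 2 to compound 3 can be read from these two limits. The compounds shown leave open whether 2-carbamoylethyl in place of methoxycarbonyl changes the reading at all.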